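A few compounds are considered here, and "the series" means these few. Any claim that something is new, unique, unknown or untested is made for them only; others in the source may bear on it.

Of the compounds shown here, three of the shared core have been tested in a functional assay on CHO cells for agonist activity at Free fatty acid receptor 2 (Homo sapiens), read by cAMP accumulation; a higher number here means a larger maximal response, a lower number a smaller maximal response. Compound 1 `CC(C)C(c1ccc(Cl)cc1)S(=O)(=O)Nc1nccs1` carries a sulfonamide; in this assay compound 1 reaches only the limit < 30%. Compound 2 `CC(C)[C@H](C(=O)NC(C)(C)C)c1ccc(Cl)cc1` is the tert-butyl amide, and in this assay compound 2 likewise gives only the limit < 30%. Compound 3 `CC(C)[C@H](C(=O)Nc1ccccc1)c1ccc(Cl)cc1` is the phenyl amide, and in this assay compound 3 also stops at the limit < 30%. The change of phenyl in place of tert-butyl on an amide-type nitrogen thus leaves a step that the two limits leave unreadable from compound 2 to compound 3, because of the limit of < 30% in this assay, at which 3 of the 3 values shown sit.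

Compound 4 `CC(C)[C@H](C(=O)Nc1ccc(F)cn1)c1ccc(Cl)cc1` differs from compound 2 in one place: 5-fluoropyridin-2-yl in place of tert-butyl on an amide-type nitrogen. Among the measured compounds shown here, the one measured step that bears on this change is the one from compound 2 to compound 3, whose size cannot be read, so no direction beyond the scatter is expected in this assay. Compound 4 is therefore estimated to stay near the limit with a step that the limit leaves unreadable from compound 2 to compound 4. In this assay compound 4 is expected to give 18%, within a range from 5% to 45%.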

Compound 4, largest response reached (reported as efficacy), in percent of the reference or control that the assay uses: 93%
For compound 4 the middle estimate is 75 percentage points below the measured one, outside the stated range (above it).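

Among the compounds shown here, at the amide-type nitrogen, 5-fluoropyridin-2-yl in place of tert-butyl gives a number at least 63 percentage points higher from compound 2 to compound 4 (beyond the scatter) in this assay, the first readable step and the first sign that this position can govern the maximal response. The same group in place of phenyl gives a number at least 63 percentage points higher from compound 3 to compound 4 (beyond the scatter), which shows that the response depends on which six-membered aromatic ring sits on this nitrogen, not merely on the presence of such a ring. The step among the earlier amides still cannot be read, and the reason lies in the assay's floor: the limit of < 30% in this assay, at which 3 of the 4 values shown sit.

The compounds shown change the ring nitrogen and the fluorine together, so they do not separate the contribution of each to the rise. A plain pyridin-2-yl or a fluorophenyl group on the same nitrogen would bear directly on that question.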